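Sulfonamide variation on the chromene core: azide to dimethylamine

This account rests on a few compounds, and the source may have more. Where it says the series, first, only, none or still open, it means among the compounds named here.

Measured so far in a functional assay on the whole organism (trachea) with Rattus norvegicus as the target; a higher number here means a larger maximal response, a lower number a smaller maximal response:
compound 1 `CC1(C)C=C(n2ccccc2=O)c2cc(S(=O)(=O)N=[N+]=[N-])ccc2O1` — 77.2%
compound 2 `CNS(=O)(=O)c1ccc2c(c1)C(n1ccccc1=O)=CC(C)(C)O2` — 83%
compound 3 `CC1(C)C=C(n2ccccc2=O)c2cc(S(=O)(=O)Nc3ccccc3)ccc2O1` — 7.85%; 88% (2 entries)

Compound 1 stands lowest of the two single numbers in this assay; its nearest neighbour is compound 2, reached by a number 5.8 percentage points higher from compound 1 to compound 2 (within the scatter). Compound 3 carries two entries that lie far apart (the several entries of compound 3 in this assay, 7.85%; 88% (2 entries)), so it gives no single number.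

Compound 4 `CN(C)S(=O)(=O)c1ccc2c(c1)C(n1ccccc1=O)=CC(C)(C)O2` differs from compound 1 by dimethylamino in place of azido on a sulfonyl sulfur. Within the data shown here, the one measured step that bears on this change is a number 5.8 percentage points higher from compound 1 to compound 2 (within the scatter), which put an amine on the same sulfonyl sulfur and stayed within the scatter. No step beyond the scatter is therefore expected from compound 1 to compound 4; the estimated step is a number 3.8 percentage points higher from compound 1 to compound 4 (within the scatter).

For compound 4 the expected value in this assay is 81%, within 62% to 95%, the range kept wide because of the spread seen in the several entries of compound 3 in this assay, 7.85%; 88% (2 entries).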

Compound 4, largest response reached (Emax), in percent of the reference or control that the assay uses: 74.1%
For compound 4 the middle estimate is 6.9 percentage points above the measured one; low and high end bracket the measured number.
By their numbers in this assay, from the lowest: compounds 4, 1 and 2 (each within the scatter of the next).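

In this assay, dimethylamino in place of azido on a sulfonyl sulfur gives a number 3.1 percentage points lower from compound 1 to compound 4 (within the scatter). Methyl in place of hydrogen on the sulfonamide nitrogen gives a number 8.9 percentage points lower from compound 2 to compound 4 (within the scatter), so the hydrogen on that nitrogen is not needed to keep the maximal response in this pair. Compound 1, compound 2 and compound 4 therefore show no separation at this position.

From the compounds shown here alone, whether a carboxylic acid or a longer alkyl chain on the sulfonamide nitrogen would hold this response remains open. Compound 3 cannot be placed against this pattern, since its entries disagree: the several entries of compound 3 in this assay, 7.85%; 88% (2 entries)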